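The compounds below may be only part of what the source reports. "The series", "measured", "known", "first", "only" and "open" are said of these compounds alone.

Measured so far:
compound 1, `CN1CCCc2ccc(NC(=O)c3ccc(-c4ccccc4)cc3)cc21` — 7.5 in a functional assay for antagonist activity at transient receptor potential cation channel subfamily V member 1 (Homo sapiens), read by FLIPR and calcium flux; on this read-out lower numbers stand for lower potency and higher numbers for higher potency (the scale is a negative logarithm)
compound 2, `CN(C)CCN1CCCc2ccc(NC(=O)c3ccc(-c4ccccc4)cc3)cc21` — 7.4

Compound 1 carries the larger of the two numbers, but its nearest neighbour is compound 2, and the step of a number 0.10 log units lower from compound 1 to compound 2 (within the scatter) lies within the scatter, so the two stand together. Compound 3, `COc1cc(-c2ccccc2)ccc1C(=O)Nc1ccc2c(c1)N(C)CCC2`, differs from compound 1 by methoxy in place of hydrogen on an aromatic carbon. For the measured compounds named here, the single measured step, a number 0.10 log units lower from compound 1 to compound 2 (within the scatter), concerns a change elsewhere and bears only loosely on this one; nothing here points to a step beyond the scatter. Compound 3 is therefore estimated at 7.4, between 6.8 and 8, an expected step of a number 0.10 log units lower from compound 1 to compound 3 (within the scatter).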

Compound 3, negative logarithm of the antagonist equilibrium constant: < 6.8
Compound 3: only a limit was reported; the forecaster's own chance of this, stated with the estimate: 5%; middle value at least 0.60 log units away from the limit.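

In this assay, methoxy in place of hydrogen on an aromatic carbon, ortho to a large group, gives a number at least 0.70 log units lower from compound 1 to compound 3 (beyond the scatter). The earlier change, on a saturated chain carbon, gave a number 0.10 log units lower from compound 1 to compound 2 (within the scatter), so this aromatic carbon is the first place shown where a change goes beyond the scatter. The value of compound 3 is a limit and not a number: the limit of < 6.8 in this assay, at which 1 of the 3 values shown sits.

As far as these compounds go, how far the potency of compound 3 actually falls stays open. So does whether a smaller group on this carbon, such as fluorine or methyl, would lower the number as well.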